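The source may hold more compounds than are shown below. What is called first, only, known or untested is meant among the compounds shown, and "the series" means these compounds.

In a functional assay on aorta (Rattus norvegicus) for inhibition (a lower number here means that less compound is needed, a higher number that more compound is needed for the effect), compound 1 (`CCNC1=NS(=O)(=O)c2cc(Cl)ccc2N1`) gives 39900 nM and compound 2 (`CCCNC1=NS(=O)(=O)c2cc(Cl)ccc2N1`) gives 55500 nM while compound 3 (`CC(C)NC1=NS(=O)(=O)c2cc(Cl)ccc2N1`) gives 36300 nM and so stands level with both, within the scatter. Compound 4 (`O=S1(=O)N=C(NC2CC2)Nc2ccc(Cl)cc21`) keeps the shared core and differs from compound 3 in one group (cyclopropyl in place of isopropyl on an amine nitrogen): cyclopropyl in place of isopropyl on an amine nitrogen. For the measured compounds named here, no measured step makes this exact change, and no measured compound carries a ring in that group. The closest evidence is three changes to the chain on that nitrogen (a 1.4-fold higher number from compound 1 to compound 2 (0.14 log units; within the scatter)), (a 1.1-fold lower number from compound 1 to compound 3 (0.04 log units; within the scatter)) and (a 1.5-fold lower number from compound 2 to compound 3 (0.18 log units; within the scatter)), each within the scatter. The step expected in this assay (a 1.0-fold lower number from compound 3 to compound 4 (0.00 log units; within the scatter)) therefore stays within the scatter too. Compound 4 is estimated at 36000 nM with a deliberately wide expected range (14000 nM to 90000 nM).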

Compound 4, half-maximal effective concentration: 191000 nM
The estimate for compound 4 lay 5.3-fold (0.72 log units) below the measured number; measured number above the stated range.
By their numbers in this assay, from the lowest: compounds 3, 1 and 2 (each within the scatter of the next); then compound 4.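

In this assay the open chains on the amine nitrogen stood level, but the cyclopropyl ring breaks from all of them: (a 5.3-fold higher number from compound 3 to compound 4 (0.72 log units; beyond the scatter)), (a 3.4-fold higher number from compound 2 to compound 4 (0.54 log units; beyond the scatter)) and (a 4.8-fold higher number from compound 1 to compound 4 (0.68 log units; beyond the scatter)), each beyond the scatter. This position therefore does respond to the group it carries, even when isopropyl and cyclopropyl have the same count of heavy atoms. No measurement shown here explains the shift. Still open, going by these compounds, is whether a larger ring, such as cyclobutyl or cyclohexyl, raises the number in the same way. Also open, on these data alone, is whether a longer chain, such as butyl, stays level with the shorter chains.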